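Dichloro Extension of the Thioether Urea Series

A few compounds are considered here, and "the series" means these few. Any claim that something is new, unique, unknown or untested is made for them only; others in the source may bear on it.

Among the compounds with values here, compound 3 `Cc1cc(C)nc(Sc2ccc(NC(=O)Nc3ccc(Cl)cc3)cc2)n1` gives the lowest of the two numbers so far in a functional assay on MCF7 cells (Homo sapiens) for cytotoxicity, read by MTT assay, with a stated time of 3 days (on this read-out higher numbers stand for weaker inhibition and lower numbers for stronger inhibition), with 35300 nM; compound 1 `Cc1cc(C)nc(Oc2ccc(NC(=O)Nc3ccc(Cl)cc3Cl)cc2)n1` sits nearest in this assay at 47800 nM, a gap within the usual scatter. Compound 2 `Cc1cc(C)nc(Sc2ccc(NC(=O)Nc3ccccc3)cc2)n1` reaches only the limit of this assay, > 50000 nM. Within the data shown here, the one measured single-point step, an at least 1.4-fold lower number from compound 2 to compound 3 (0.15 log units; that floor lies within the scatter), is a change whose floor lies within the scatter, so its size is not fixed; the evidence here is the limit of > 50000 nM in this assay, at which 1 of the 3 values shown sits.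

Compound 4 `Cc1cc(C)nc(Sc2ccc(NC(=O)Nc3ccc(Cl)cc3Cl)cc2)n1` is the next point. The change is chloro in place of hydrogen on an aromatic carbon, placed ortho to a large group and meta to a chloro group. Among the measured compounds shown here, the only step of the same kind is that from compound 2 to compound 3, and it says little about size; the pair of compound 1 and compound 3 shows two numbers within the scatter of each other. No step beyond the scatter is therefore expected in this assay, and the expected change from compound 3 to compound 4 is a 1.1-fold higher number from compound 3 to compound 4 (0.05 log units; within the scatter). The estimate for compound 4 in this assay is 40000 nM, within 20000 nM to 80000 nM.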

Compound 4, half-maximal inhibitory concentration: > 50000 nM
Compound 4 gave a limit, no number (the forecaster's own chance of this, stated with the estimate: 25%); at least 1.2-fold (0.09 log units) between middle value and limit.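

Adding chloro ortho to a large group and meta to a chloro group, the change from 4-chlorophenyl to 2,4-dichlorophenyl, gives no lower number in this assay: the step is an at least 1.4-fold higher number from compound 3 to compound 4 (0.15 log units; that floor lies within the scatter), and compound 4 stands at a limit of the assay, not at a number. With 2,4-dichlorophenyl held constant, the series now also has a single-place comparison of the sulfanyl and oxy links, which reads an at least 1.0-fold higher number from compound 1 to compound 4 (0.01 log units; that floor lies within the scatter). Compound 2 and compound 4 both stand at limits, so the step between them cannot be read: the limit of > 50000 nM in this assay, at which 2 of the 4 values shown sit.

Going by these compounds, the true size of both readable steps remains open. Also open, on these data alone, is how an amine or a carboxylic acid in place of the chloro of compound 3 would read in this assay.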